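The compounds below may be only part of what the source reports. "The series", "measured", "known", "first", "only" and "open" are said of these compounds alone.

In a functional assay on A549 cells (Homo sapiens) for inhibition, read by MTT assay, with a stated time of 72 h (a higher number here means a weaker inhibitor, a lower number a stronger inhibitor), three compounds with a shared core have been measured: compound 1 (`Cc1ccccc1-c1cc(C(=O)N2CCC3(CC2)CC(=O)c2nn(C(C)(C)C)cc2O3)c2ccccc2n1`) gives 1880 nM, compound 2 (`CC(C)(C)n1cc2c(n1)C(=O)CC1(CCN(C(=O)c3cc(-c4ccc(Cl)cc4)nc4ccccc34)CC1)O2`) gives 2330 nM and compound 3 (`COc1ccc(-c2cc(C(=O)N3CCC4(CC3)CC(=O)c3nn(C(C)(C)C)cc3O4)c3ccccc3n2)cc1OC`) gives 2030 nM. Compound 2 therefore stands within the scatter of both other compounds. Compound 4 (`CN(C)c1ccc(-c2cc(C(=O)N3CCC4(CC3)CC(=O)c3nn(C(C)(C)C)cc3O4)c3ccccc3n2)cc1`) has dimethylamino in place of chloro on an aromatic carbon, para to a large group: dimethylamino in place of chloro on an aromatic carbon. The measured steps that bear on this change alter the same aryl group: a 1.2-fold higher number from compound 1 to compound 2 (0.09 log units; within the scatter), a 1.1-fold higher number from compound 1 to compound 3 (0.03 log units; within the scatter) and a 1.1-fold lower number from compound 2 to compound 3 (0.06 log units; within the scatter). All three lie within the scatter, so no step beyond it is expected in this assay. The expected change is a 1.1-fold lower number from compound 2 to compound 4 (0.05 log units; within the scatter). Compound 4 is estimated at 2100 nM, with a range of 1000 nM to 4500 nM.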

Compound 4, half-maximal inhibitory concentration: 1150 nM
Compound 4: middle estimate off by 1.8-fold (0.26 log units), on the high side; the measured number falls inside the stated range.
By their numbers in this assay, from the lowest: compounds 4, 1, 3 and 2 (each within the scatter of the next, the first and the last beyond it).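

In this assay, among these compounds, this position had so far given only steps within the scatter, and dimethylamino in place of chloro gives the first one beyond it, a modest 2.0-fold lower number from compound 2 to compound 4 (0.31 log units; beyond the scatter) at this place. The other two steps, a 1.8-fold lower number from compound 3 to compound 4 (0.25 log units; within the scatter) and a 1.6-fold lower number from compound 1 to compound 4 (0.21 log units; within the scatter), stay within the scatter, so compound 4 is set apart from compound 2 alone. No measurement given here accounts for this step.

The compounds shown leave open whether a plain amino group, a morpholine or a carboxylic acid at this place would fall with compound 4 or with compound 2.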